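The compounds below may be only part of what the source reports. "The series", "measured", "known", "first", "only" and "open" are said of these compounds alone.

Measured compounds:
compound 1, `Oc1cccc(-c2cc(-c3ccc(Cl)cc3)nc(-c3cccs3)c2)c1`, 15.1% in an assay on isolated protein for inhibition of DNA topoisomerase 1 (Homo sapiens), with a stated time of 30 min, tested at 100 uM; a lower number here means a weaker effect, a higher number a stronger effect of the compound at the concentration tested
compound 2, `Oc1ccc(-c2cc(-c3ccc(Cl)cc3)nc(-c3cccs3)c2)cc1`, 38.8%
compound 3, `Oc1cccc(-c2cc(-c3ccc(Cl)cc3)nc(-c3ccco3)c2)c1`, 27.1%

Compound 1 gives the lowest of the three numbers in this assay. Compound 3 sits nearest to it, the step being a number 12 percentage points higher from compound 1 to compound 3 (beyond the scatter), while compound 2 lies furthest, with a number 23.7 percentage points higher from compound 1 to compound 2 (beyond the scatter). Both of those steps change a group other than the chlorinated ring, so neither touches the part of the molecule that is altered in the unmeasured compound 4, `Oc1cccc(-c2cc(-c3cccc(Cl)c3)nc(-c3cccs3)c2)c1`.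

The change from compound 1 to compound 4 is 3-chlorophenyl in place of 4-chlorophenyl on an aromatic carbon. Going by the values given here, no measured pair shows what moving the chlorine from one position of this ring to another does in this assay, so the direction of the step cannot be read from the data. The account therefore expects a step that most likely stays within the usual scatter: a number 3.9 percentage points higher from compound 1 to compound 4 (within the scatter) is the estimated change from compound 1 to compound 4 in this assay. On that basis compound 4 is expected to give about 19% in this assay, with a plausible range from 5% to 40%.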

Compound 4, a percentage reported as inhibition, at one concentration (the size of the read-out at that concentration, not a potency): 7.6%
Beside the measured number, compound 4's estimate is 11.4 percentage points above it, and the stated range covers the measured number.
By their numbers in this assay, from the lowest: compounds 4 and 1 (each within the scatter of the next); then compound 3; then compound 2.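

Going by these compounds alone, the first reading at the chlorinated ring comes from the group next to the ring nitrogen: in this assay, 3-chlorophenyl in place of 4-chlorophenyl gives a number 7.5 percentage points lower from compound 1 to compound 4 (within the scatter) and so does not separate the two compounds. The earlier steps shown here, at the hydroxyphenyl and thiophen-2-yl groups, lay beyond the scatter, whereas this shift of the chlorine on the core of compound 1 does not. Nothing shown here offers an explanation for this result.

From the compounds shown here alone, whether the same shift of the chlorine stays within the scatter when the core also carries a 4-hydroxyphenyl or furan-2-yl group remains open. The compounds shown also leave open what an amine or a carboxylic acid in place of the chlorine would do to the read-out.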